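The source may report more compounds than this note shows. Statements on the series, on what has been measured and on what is new or still open speak of the compounds shown alone.

Measured so far in a functional assay on PRK cells (Oryctolagus cuniculus) for cytotoxicity; a lower number here means that less compound is tolerated, a higher number that more compound is tolerated:
compound 1, `Nc1ncnc2c1ncn2CC(O)C(=O)OCCO`: > 400 ug/mL
compound 2, `CCCCCCCCOC(=O)C(O)Cn1cnc2c(N)ncnc21`: 100 ug/mL
compound 3, `CC(C)OC(=O)C(O)Cn1cnc2c(N)ncnc21`: > 400 ug/mL

The value of compound 3 is a limit of the assay, not a number. Compound 1 sits at the same limit (the limit of > 400 ug/mL in this assay, at which 2 of the 3 values shown sit). Only compound 2 gives a number. Among the compounds with values here, two measured steps bear on the next change: an at least 4.0-fold higher number from compound 2 to compound 3 (0.60 log units; beyond the scatter) and an at least 4.0-fold lower number from compound 1 to compound 2 (0.60 log units; beyond the scatter); in both, the larger group on the oxygen next to a carbonyl group goes with the lower number. Compound 4, `Nc1ncnc2c1ncn2CC(O)C(=O)OCc1ccco1`, differs from compound 3 by (furan-2-yl)methyl in place of isopropyl on an oxygen next to a carbonyl group. The entering group is larger than isopropyl but smaller than octyl, so the step is expected to be a number no higher from compound 3 to compound 4 (the limit leaves the size open), at most a small lowering, with a fair chance that only the limit is reached again. Compound 4 is estimated at 400 ug/mL, range 150 ug/mL to 400 ug/mL.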

Compound 4, minimum cytotoxic concentration: 40 ug/mL
Estimate against measurement, compound 4: 10-fold (1.00 log units) above; the measured number lies below the stated range.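

In this assay, (furan-2-yl)methyl on this oxygen gives an at least 10-fold lower number from compound 3 to compound 4 (1.00 log units; beyond the scatter), and against the 2-hydroxyethyl ester it gives an at least 10-fold lower number from compound 1 to compound 4 (1.00 log units; beyond the scatter). Size of the group alone no longer orders the series: octyl is the larger group, yet the change to (furan-2-yl)methyl gives a 2.5-fold lower number from compound 2 to compound 4 (0.40 log units; beyond the scatter). The first two steps give only a minimum size, as compound 1 and compound 3 are limits and not numbers: the limit of > 400 ug/mL in this assay, at which 2 of the 4 values shown sit.

Open, on these data alone, is whether a benzyl group on this oxygen behaves like (furan-2-yl)methyl. Also open, as far as these compounds go, is whether a butyl chain already lowers the number.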